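Moving the nitrile: 4-cyanophenyl to 2-cyanophenyl

The compounds below may be only part of what the source reports. "The series", "measured", "known", "first", "only" and "open" are said of these compounds alone.

compound 1 `COc1cc2c(Nc3ccc(C#N)cc3)ncnc2cc1OCCCN(C)C`: > 100000 nM (a limit)
compound 2 `COc1cc2c(Nc3ccc(C#N)cc3)ncnc2cc1OCCCN1CCC(CO)CC1`: 61800 nM
compound 3 `COc1cc2c(Nc3ccc(C#N)cc3)ncnc2cc1OCCCN1CCN(C)CC1`: 13800 nM

In a functional assay on HepG2 cells (Homo sapiens) for antiproliferative activity, read by MTT assay, with a stated time of 72 h (a lower number here means a stronger inhibitor, a higher number a weaker inhibitor), compound 3 gives 13800 nM, the lowest number of the series. Compound 4 `COc1cc2c(Nc3ccccc3C#N)ncnc2cc1OCCCN1CCN(C)CC1` has 2-cyanophenyl in place of 4-cyanophenyl on a nitrogen on an aromatic ring. The measured steps, an at least 7.2-fold lower number from compound 1 to compound 3 (0.86 log units; beyond the scatter) and a 4.5-fold lower number from compound 2 to compound 3 (0.65 log units; beyond the scatter), change only the group at the end of the chain. They set a rough scale for the series, but neither measures this change or gives it a direction. The expected step is a 1.3-fold higher number from compound 3 to compound 4 (0.12 log units; within the scatter), with nothing beyond the scatter anticipated. The estimated value for compound 4 is 18000 nM, within an expected range of 5000 nM to 60000 nM.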

Compound 4, half-maximal inhibitory concentration: 26400 nM
Compound 4: middle estimate off by 1.5-fold (0.17 log units), on the low side; low and high end bracket the measured number.
By their numbers in this assay, from the lowest: compounds 3 and 4 (each within the scatter of the next); then compound 2. At a limit, above all of these: compound 1.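

Going by these compounds alone, with 4-methylpiperazin-1-yl at the end of the chain, the only change here away from that chain end, 2-cyanophenyl in place of 4-cyanophenyl, reads in this assay as a 1.9-fold higher number from compound 3 to compound 4 (0.28 log units; within the scatter) and so stays within the scatter. For this pair, moving the nitrile therefore shows no clear effect on the number. No measurement at hand bears on a cause for this step. Open, as far as these compounds go, is whether the same move holds with 4-(hydroxymethyl)piperidin-1-yl or dimethylamino at the chain end. Also open, from the compounds shown here alone, is how a primary amide or a carboxylic acid in place of the nitrile would read.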